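Removing a methoxy group from a hydroxamic acid growth inhibitor

The source may report more compounds than this note shows. Statements on the series, on what has been measured and on what is new or still open speak of the compounds shown alone.

Of the compounds shown here, two have been measured in a functional assay on ACHN cells (Homo sapiens) for antiproliferative activity; on this read-out higher numbers stand for weaker inhibition of growth and lower numbers for stronger inhibition of growth. Compound 1 `COc1cccc(CN2CC=C(CCC(=O)NO)C2=O)c1` gives 4430 nM in this assay, and compound 2 `COc1cccc(CCCN2CC=C(CCC(=O)NO)C2=O)c1` gives 2480 nM. For the measured compounds named here, of these two numbers the one for compound 1 is the higher, but the gap to compound 2 lies within the usual scatter of repeated measurements, so the two cannot be told apart on this evidence. Going by the values given here, no step between measured compounds is available for the change now in question.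

Compound 3 `O=C(CCC1=CCN(Cc2ccccc2)C1=O)NO` has not yet been measured. Compared with compound 1 it carries hydrogen in place of methoxy on an aromatic carbon. Among the compounds with values here, nothing among the measured compounds shows what dropping a methoxy group does on this read-out, so there is no basis to expect a shift in either direction. The expectation is therefore that compound 3 behaves much like compound 1, with a 1.1-fold higher number from compound 1 to compound 3 (0.05 log units; within the scatter) amounting to no step beyond the scatter. On this reasoning compound 3 is estimated at 5000 nM in this assay, with a plausible range from 2000 nM to 12000 nM.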

Compound 3, concentration for 50% growth inhibition: 1080 nM
For compound 3 the middle estimate is 4.6-fold (0.67 log units) above the measured one, and the stated range ends above it.
By their numbers in this assay, from the lowest: compound 3; then compounds 2 and 1 (each within the scatter of the next).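

In this assay, replacing the methoxy group with hydrogen on the aromatic carbon meta to a large group gives a 4.1-fold lower number from compound 1 to compound 3 (0.61 log units; beyond the scatter) and so a stronger inhibition of growth, a step large enough to count as a real change. For the compounds shown here, this is the first measured evidence about this position, and it shows that the methoxy group is not needed for growth inhibition on the core of compound 1, since the compound without it does better. Going by these compounds alone, the measurements show only that the number falls with this change and offer no information on why it does so.

Going by these compounds, it remains open whether the plain hydrogen is itself the best choice here, or whether another small substituent on the same aromatic carbon, such as a fluorine atom, a hydroxyl group or an amine, would give a number closer to that of compound 3 or closer to that of compound 1. On these data alone, it is also open whether removing the methoxy group from compound 2, with its longer chain between the ring and the core, would bring a step of similar size.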